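This account rests on a few compounds, and the source may have more. Where it says the series, first, only, none or still open, it means among the compounds named here.

The measured compounds in this set are:

Compound 1, `CCOC(=O)c1c(O)c2cccnc2n(-c2ccccc2)c1=O`: 15.5%
Compound 2, `O=C(Nc1ccccn1)c1c(O)c2cccnc2n(-c2ccccc2)c1=O`: 14.6%
Compound 3, `CCCCNC(=O)c1c(O)c2cccnc2n(-c2ccccc2)c1=O`: 20.4%

All three share one core and differ only in the group attached to a carbonyl carbon on that core. In a functional assay on the whole organism for inhibition, with Rattus norvegicus as the target, read by cytopathic effect and paw edema, at a dose of 100 mg/kg by the oral route (on this read-out higher numbers stand for more inhibition at the one dose given (going by the name of the read-out) and lower numbers for less inhibition), compound 3 gives the highest of the three numbers, yet its lead is slight: the step of a number 4.9 percentage points higher from compound 1 to compound 3 (within the scatter) and the step of a number 5.8 percentage points higher from compound 2 to compound 3 (within the scatter) both stay within the usual scatter, so the three compounds cannot be ranked against each other on this evidence.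

Compound 4, `O=C(NCc1ccccc1)c1c(O)c2cccnc2n(-c2ccccc2)c1=O`, is the next variation at the same position. Relative to compound 3 the change is phenyl in place of propyl on a saturated chain carbon bound to an amide-type nitrogen.

Within the data shown here, three measured steps bear on this change, since each of them also alters the group on the carbonyl carbon or on the amide-type nitrogen: a number 0.9 percentage points lower from compound 1 to compound 2 (within the scatter), a number 4.9 percentage points higher from compound 1 to compound 3 (within the scatter) and a number 5.8 percentage points higher from compound 2 to compound 3 (within the scatter). The last of these is the closest model, as it trades an aromatic ring for a plain chain on the amide-type nitrogen, and it, like the others, lies within the scatter. Nothing in this set therefore points to a step beyond the scatter in this assay for compound 4, in either direction.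

On that basis compound 4 is expected to give about 18% in this assay, with a likely range from 8% to 28%. The expected step of a number 2.4 percentage points lower from compound 3 to compound 4 (within the scatter) is thus estimated to be small.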

Compound 4, a percentage reported as inhibition, in the whole organism at one dose (the size of the read-out at that dose, not a potency): 11.3%
Compound 4: middle estimate off by 6.7 percentage points, on the high side; the measured number falls inside the stated range.
By their numbers in this assay, from the lowest: compounds 4, 2, 1 and 3 (each within the scatter of the next).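

Among these compounds, compound 4 brings a ring onto the saturated chain for the first time, and this swap of the butyl chain for benzyl gives the largest step yet at this position (a number 9.1 percentage points lower from compound 3 to compound 4 (within the scatter)) in this assay, though it still does not clear the scatter. Benzylamino also stays within the scatter when set against the pyridin-2-yl amide (a number 3.3 percentage points lower from compound 2 to compound 4 (within the scatter)) and against the ethoxy group of the ester (a number 4.2 percentage points lower from compound 1 to compound 4 (within the scatter)), so four different groups on the carbonyl carbon now remain unseparated, whether the amide nitrogen carries a plain chain, an aromatic ring or a ring on a saturated chain carbon. No measurement here gives a reason for these small differences.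

What the compounds shown leave open is whether any group on this carbonyl carbon can move the number beyond the scatter, for example a carboxylic acid, a chain much longer than butyl, or a chain ending in an amine. Also open, going by these compounds, is whether a chlorine atom or a methoxy group on the benzyl ring would change the picture at this one dose.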